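Working notes on the aryl substituent series, compound 4

The source may report more compounds than this note shows. Statements on the series, on what has been measured and on what is new or still open speak of the compounds shown alone.

Compound 3 (`Cc1ccc(C2=NN(C(=S)Nc3ccccc3)C(c3ccc4c(c3)OCCO4)C2)cc1`) carries a methyl on the aryl ring attached to the shared core. In a functional assay on WM 266-4 cells (Homo sapiens) for antiproliferative activity, read by MTT assay, with a stated time of 48 h (a lower number here means a stronger inhibitor of growth, a higher number a weaker inhibitor of growth), compound 3 gives 10300 nM, the lowest of the two numbers in hand. Compound 1 (`Fc1ccc(C2=NN(C(=S)Nc3ccccc3)C(c3ccc4c(c3)OCCO4)C2)cc1`), the fluoro analogue, gives 22500 nM in this assay. Compound 2 (`S=C(Nc1ccccc1)N1N=C(c2ccc(Cl)cc2)CC1c1ccc2c(c1)OCCO2`), the chloro analogue, reaches only the limit of this assay at > 200000 nM. The measured steps read a 2.2-fold lower number from compound 1 to compound 3 (0.34 log units; beyond the scatter) and an at least 19-fold lower number from compound 2 to compound 3 (1.28 log units; beyond the scatter); the second rests on (the limit of > 200000 nM in this assay, at which 1 of the 3 values shown sits).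

Compound 4 (`CSc1ccc(C2=NN(C(=S)Nc3ccccc3)C(c3ccc4c(c3)OCCO4)C2)cc1`) differs from compound 3 by methylsulfanyl in place of methyl on an aromatic carbon. Among the compounds with values here, no measured step exchanges methyl for a sulfur-bearing group, so the two steps into compound 3 are the only guide: one substituent swap at this position gave a 2.2-fold lower number from compound 1 to compound 3 (0.34 log units; beyond the scatter), the other at least 19-fold lower number from compound 2 to compound 3 (1.28 log units; beyond the scatter), and the outcome for a different substituent is open in either direction. Compound 4 is expected to show a 1.9-fold higher number from compound 3 to compound 4 (0.29 log units; within the scatter), a weakening of uncertain size. The estimate for compound 4 is 20000 nM, with a range from 5000 nM to 100000 nM.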

Compound 4, concentration for 50% growth inhibition: 197000 nM
Compound 4: middle estimate off by 9.9-fold (0.99 log units), on the low side; the whole stated range lies below it.
By their numbers in this assay, from the lowest: compound 3; then compound 1; then compound 4. At a limit, above all of these: compound 2.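

In this assay, a large step at this position is no longer confined to the chloro swap (an at least 19-fold lower number from compound 2 to compound 3 (1.28 log units; beyond the scatter)): methylsulfanyl also gives a much weaker result (a 19-fold higher number from compound 3 to compound 4 (1.28 log units; beyond the scatter)). Fluoro remains the only other substituent shown that stays near the methyl result, while methylsulfanyl falls well behind it (an 8.8-fold higher number from compound 1 to compound 4 (0.94 log units; beyond the scatter)), so this position is sensitive to more than a change of halogen. Compound 2 stands at a limit: the limit of > 200000 nM in this assay, at which 1 of the 4 values shown sits.
The swap from chloro to methylsulfanyl gives only a floor (an at least 1.0-fold lower number from compound 2 to compound 4 (0.00 log units; that floor lies within the scatter)).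

The compounds shown leave open whether the loss follows the sulfur atom or the added heavy atom, which a methoxy or ethyl group at this place would help to separate. They also do not show how an amine or a carboxylic acid would behave here.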